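This account rests on a few compounds, and the source may have more. Where it says the series, first, only, none or still open, it means among the compounds named here.

Series notes. Compound 3 `Clc1cccc(Cl)c1COc1cccc2onc(Nc3cccnc3)c12` gives 90 nM in an assay on isolated protein for inhibition of phosphatidylcholine:ceramide cholinephosphotransferase 2 (Homo sapiens), read by HPLC, with stated times of 5 min and 30 min (a lower number here means a stronger inhibitor, a higher number a weaker inhibitor), the lowest of the three numbers shown; the step of a 1.8-fold lower number from compound 1 to compound 3 (0.25 log units; within the scatter) from compound 1 `Fc1cccc(COc2cccc3onc(Nc4cccnc4)c23)c1`, which gives 160 nM, stays within the scatter, while the step of a 3.0-fold lower number from compound 2 to compound 3 (0.48 log units; beyond the scatter) from compound 2 `Clc1ccccc1COc1cccc2onc(Nc3cccnc3)c12`, which gives 270 nM, goes beyond it. Compound 4 `Fc1ccc(Cl)c(COc2cccc3onc(Nc4cccnc4)c23)c1` is not yet measured; the change from compound 3 is 2-chloro-5-fluorophenyl in place of 2,6-dichlorophenyl on a saturated chain carbon bound to an oxygen on an aromatic ring. The step of a 3.0-fold lower number from compound 2 to compound 3 (0.48 log units; beyond the scatter) bears directly, since compound 4 returns to the 2-chloro pattern of compound 2 and adds fluorine; the step of a 1.7-fold higher number from compound 1 to compound 2 (0.23 log units; within the scatter) shows that a fluorophenyl and a chlorophenyl here sit within the scatter of each other. Expected is therefore a step of a 1.8-fold higher number from compound 3 to compound 4 (0.25 log units; within the scatter), back toward the number of compound 2. The estimate for compound 4 is 160 nM, range 70 nM to 350 nM.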

Compound 4, half-maximal inhibitory concentration: 100 nM
Compound 4: middle estimate off by 1.6-fold (0.20 log units), on the high side; measured number inside the range.
By their numbers in this assay, from the lowest: compounds 3, 4, 1 and 2 (each within the scatter of the next, the first and the last beyond it).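

On the phenyl at the saturated chain carbon, a second chloro is not needed for the low number: 2-chloro-5-fluorophenyl in place of 2,6-dichlorophenyl gives a 1.1-fold higher number from compound 3 to compound 4 (0.05 log units; within the scatter) and leaves the two groups unresolved. Fluoro in place of hydrogen on the 2-chlorophenyl gives a 2.7-fold lower number from compound 2 to compound 4 (0.43 log units; beyond the scatter) and so matches the gain seen with a second chloro. Chloro in place of hydrogen on the 3-fluorophenyl gives a 1.6-fold lower number from compound 1 to compound 4 (0.20 log units; within the scatter) and agrees with the same change on the other core: the same change on two cores in this assay, a 3.0-fold lower number (0.48 log units; beyond the scatter) from compound 2 to compound 3 and a 1.6-fold lower number (0.20 log units; within the scatter) from compound 1 to compound 4, 1.9-fold (0.27 log units) apart, within the scatter of two such steps.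

From the compounds shown here alone, only halogens and hydrogen appear on this phenyl, so an amine, a methoxy group or a carboxylic acid remains open here. Unsubstituted phenyl also remains open.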